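The source may report more compounds than this note shows. Statements on the series, on what has been measured and on what is new or still open speak of the compounds shown alone.

Measured in a functional assay on A2780 cells (Homo sapiens) for inhibition, read by MTT assay, with a stated time of 72 h; on this read-out higher numbers stand for weaker inhibition of growth and lower numbers for stronger inhibition of growth:

compound 1 `CC(C)(C)c1ccc(CNCCCNS(=O)(=O)c2cc(C(F)(F)F)cc(C(F)(F)F)c2)cc1`, 2900 nM
compound 2 `O=S(=O)(NCCCNCc1ccc(C(F)(F)F)cc1)c1cc(C(F)(F)F)cc(C(F)(F)F)c1`, 2800 nM
compound 3 `O=S(=O)(NCCCNCc1ccc(Br)cc1)c1cc(C(F)(F)F)cc(C(F)(F)F)c1`, 2600 nM

Compound 3 sits together with the other two: the steps of a 1.1-fold lower number from compound 1 to compound 3 (0.05 log units; within the scatter) and a 1.1-fold lower number from compound 2 to compound 3 (0.03 log units; within the scatter) are both within the scatter, so the three numbers cannot be told apart. Compound 4 `O=S(=O)(NCCCNCc1ccc(-c2ccccc2)cc1)c1cc(C(F)(F)F)cc(C(F)(F)F)c1` differs from compound 3 by phenyl in place of bromo on an aromatic carbon. Among the compounds with values here, every measured step so far swaps the group at this same aromatic carbon, and none moved the read-out: a 1.0-fold lower number from compound 1 to compound 2 (0.02 log units; within the scatter), a 1.1-fold lower number from compound 1 to compound 3 (0.05 log units; within the scatter) and a 1.1-fold lower number from compound 2 to compound 3 (0.03 log units; within the scatter). The step to a phenyl is larger in size than those swaps, but the data give no step beyond the scatter for any change at this place. Compound 4 is therefore expected to show no change at the digits printed from compound 3 to compound 4 (within the scatter), that is no step beyond the scatter. The estimate for compound 4 is 2600 nM, within 1200 nM to 5500 nM.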

Compound 4, concentration for 50% growth inhibition: 2600 nM
For compound 4 middle estimate and measured number coincide at the digits printed, within the range that was stated.
By their numbers in this assay, from the lowest: compounds 3, 4, 2 and 1 (each within the scatter of the next).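

In this assay, replacing bromo with phenyl puts a whole aromatic ring at this aromatic carbon, yet the result is (no change at the digits printed from compound 3 to compound 4 (within the scatter)). The comparisons with the other two groups agree (a 1.1-fold lower number from compound 2 to compound 4 (0.03 log units; within the scatter); a 1.1-fold lower number from compound 1 to compound 4 (0.05 log units; within the scatter)), so across these four compounds, six heavy atoms and a ring fit here with no step beyond the scatter. Nothing available accounts for this flat result. Still open, as far as these compounds go, is whether an amine or a carboxylic acid at this carbon would move the number. A longer chain in the shared core is also untested among the compounds shown.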